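This account rests on a few compounds, and the source may have more. Where it says the series, first, only, none or still open, it means among the compounds named here.

Measured so far in a functional assay on a cell-free system (plasma, Homo sapiens), with a stated time of 3 min; on this read-out lower numbers stand for stronger inhibition and higher numbers for weaker inhibition:

- compound 1 `O=C(NCc1cc(Cl)ccc1-n1cnnn1)[C@@H]1CCNN1C(=O)[C@H](O)c1ccccc1` gives 930 nM
- compound 2 `CC(C)(C)[C@@H](O)C(=O)N1NCC[C@H]1C(=O)NCc1cc(Cl)ccc1-n1cnnn1` gives 1700 nM
- compound 3 `CC(C)(C)[C@@H](O)C(=O)N1CSC[C@H]1C(=O)NCc1cc(Cl)ccc1-n1cnnn1` gives 1200 nM

Compound 1 and compound 3 both lie within the usual scatter of compound 2 at 1700 nM and no order can be read among the three.

Compound 4 `CC(C)(C)C[C@@H](O)C(=O)N1NCC[C@H]1C(=O)NCc1cc(Cl)ccc1-n1cnnn1` has not yet been measured. It keeps the core of compound 2 and changes one group: neopentyl in place of tert-butyl on a saturated chain carbon bound to a carbonyl carbon and an oxygen on a saturated carbon.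

Going by the values given here, only one measured step concerns that place. Among the compounds with values here, with a 1.8-fold higher number from compound 1 to compound 2 (0.26 log units; within the scatter) as the only guide there, no step beyond the scatter is expected in this assay and no direction can be favoured. One step is thin evidence, so the range is kept wide.

The estimated step is a 1.2-fold lower number from compound 2 to compound 4 (0.08 log units; within the scatter) and it is expected to stay within the scatter.

For compound 4 the estimated value is 1400 nM with an expected range of 450 nM to 4200 nM on this read-out.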

Compound 4, half-maximal inhibitory concentration: 1300 nM
For compound 4 the middle estimate is 1.1-fold (0.03 log units) above the measured one; the range from low to high includes it.
By their numbers in this assay, from the lowest: compounds 1, 3, 4 and 2 (each within the scatter of the next).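

At the saturated chain carbon bound to a carbonyl carbon and an oxygen, neopentyl now stands as a third carbon group, and in this assay the exchange for tert-butyl gives a 1.3-fold lower number from compound 2 to compound 4 (0.12 log units; within the scatter). The exchange for phenyl gives a 1.4-fold higher number from compound 1 to compound 4 (0.15 log units; within the scatter), so with both steps inside the scatter, this read-out does not separate phenyl, tert-butyl and neopentyl at this place, whether the group has a ring or not. No measurement at hand offers an explanation for this lack of separation.

From the compounds shown here alone, whether any group can move the read-out beyond the scatter at this place remains open, for example an amine, a carboxylic acid or a longer chain than neopentyl. Also open, going by these compounds, is whether neopentyl behaves the same way on the core of compound 3.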